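The compounds below may be only part of what the source reports. "The series", "measured", "known", "first", "only" and "open" are said of these compounds alone.

So far, two compounds have been tested in a functional assay on L1210 cells (Mus musculus) for inhibition; a higher number here means a weaker inhibitor, a lower number a stronger inhibitor. Compound 1 `O=C1/C(=C/c2cccc(Cl)c2)Cc2ccccc21` gives 41200 nM, and compound 2 `O=C1/C(=C/c2ccc(Br)cc2)Cc2ccccc21` gives 64800 nM. These two numbers lie within the usual scatter of repeated measurements, so they cannot be told apart, and compound 1 stands together with compound 2 rather than clear of it. Both are also large numbers on this scale, which is to say weak inhibition.

The next compound to be measured is compound 3 `Cc1cccc(/C=C2\Cc3ccccc3C2=O)c1`, which differs from compound 1 in one place: methyl in place of chloro on an aromatic carbon. Going by the values given here, no measured pair shows what this exchange does, so the data offer no direct guide. Among the compounds with values here, the only anchor is compound 1 at 41200 nM. With so little to go on, no step beyond the scatter is expected, in either direction, though a wide range is warranted. The estimated change is a 1.2-fold higher number from compound 1 to compound 3 (0.08 log units; within the scatter). For compound 3 the expected value is 50000 nM, with an estimated range of 20000 nM to 120000 nM.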

Compound 3, half-maximal inhibitory concentration: 50400 nM
Beside the measured number, compound 3's estimate is 1.0-fold (0.00 log units) below it; the measured number falls inside the stated range.
By their numbers in this assay, from the lowest: compounds 1, 3 and 2 (each within the scatter of the next).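

In this assay, putting methyl in place of chloro on this aromatic carbon gives a 1.2-fold higher number from compound 1 to compound 3 (0.09 log units; within the scatter), so the two numbers cannot be told apart. Going by these compounds alone, this is the first measured pair that differs in one place, and thus the first direct look at this position. It shows that, in this one exchange, a chloro and a methyl, each of a single heavy atom and with no hydrogen-bond donor, acceptor or net charge, give the same result within the scatter, and no measured property is available to explain this match.

From the compounds shown here alone, a single exchange between two such small groups says little about groups of a different make-up, so it remains open whether an amine, a carboxylic acid or a methoxy group on this carbon would give a number clearly apart from that of compound 1. Also open, going by these compounds, is whether any group here could take compound 1, at 41200 nM, to a clearly lower number and so to stronger inhibition.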